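Working notes: naphthalen-2-yl on the carbonyl carbon

This account rests on a few compounds, and the source may have more. Where it says the series, first, only, none or still open, it means among the compounds named here.

Measured in a functional assay on PC-3 cells (Homo sapiens) for inhibition, read by MTT assay, with a stated time of 48 h; on this read-out higher numbers stand for weaker inhibition and lower numbers for stronger inhibition:
- Compound 1 `COc1cc(-c2nnc(SCC(=O)c3ccccc3)n2-c2ccc(N(C)C)cc2)cc(OC)c1OC`: 38600 nM
- Compound 2 `COc1ccc(C(=O)CSc2nnc(-c3cc(OC)c(OC)c(OC)c3)n2-c2ccc(N(C)C)cc2)cc1O`: > 100000 nM

The entry for compound 2 is a limit of the assay and not a number. It gives (the limit of > 100000 nM in this assay, at which 1 of the 2 values shown sits), so compound 2 has no exact position in the series, and any step from it is bounded on one side only.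

Compound 3 `COc1cc(-c2nnc(SCC(=O)c3ccc4ccccc4c3)n2-c2ccc(N(C)C)cc2)cc(OC)c1OC` carries naphthalen-2-yl in place of 3-hydroxy-4-methoxyphenyl on a carbonyl carbon.

Within the data shown here, one measured step bears on this change: an at least 2.5-fold higher number from compound 1 to compound 2 (0.41 log units; beyond the scatter), with 3-hydroxy-4-methoxyphenyl in place of phenyl on a carbonyl carbon. Compound 3 gives up the group that entered in that step, so compound 1 at 38600 nM is the nearest reference. Naphthalen-2-yl is not phenyl, however, and a single step is thin support, so the range stays wide and a second limit remains possible.

In this assay a modest move to a lower number, meaning stronger inhibition, is expected: an at least 3.5-fold lower number from compound 2 to compound 3 (0.55 log units; beyond the scatter).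

For compound 3 the estimate is 28000 nM, with an expected range from 8000 nM to 90000 nM.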

Compound 3, half-maximal inhibitory concentration: 18100 nM
The estimate for compound 3 lay 1.5-fold (0.19 log units) above the measured number; measured number inside the range.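

In this assay, the position on the carbonyl carbon now shows a change toward stronger inhibition, where the earlier step had moved only toward weaker inhibition: naphthalen-2-yl in place of phenyl gives a 2.1-fold lower number from compound 1 to compound 3 (0.33 log units; beyond the scatter). Naphthalen-2-yl in place of 3-hydroxy-4-methoxyphenyl gives an at least 5.5-fold lower number from compound 2 to compound 3 (0.74 log units; beyond the scatter), so the two groups on this carbonyl carbon are clearly separated in this series. The entry for compound 2 is a limit and not a number, so that step is bounded on one side only: the limit of > 100000 nM in this assay, at which 1 of the 3 values shown sits.

The step from compound 1 to compound 3 adds a second six-membered aromatic ring, and the step from compound 2 to compound 3 removes the hydroxy and methoxy groups together while adding that ring, so the compounds shown cannot assign the differences to any one of these parts. Also open, going by these compounds, is how a naphthalen-1-yl group, a cyclohexyl group, or a phenyl carrying only a hydroxy group or only a methoxy group would read in this assay.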